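From Vinylamino to Methylpiperazinyl: the Expected Step

The source may report more compounds than this note shows. Statements on the series, on what has been measured and on what is new or still open speak of the compounds shown alone.

Compound 3 `C=CNCc1cc(-c2c(C(=O)NCC)noc2-c2cc(C(C)C)c(O)cc2O)on1` gives 121 nM in a functional assay on HCT-116 cells (Homo sapiens) for inhibition (a higher number here means a weaker inhibitor, a lower number a stronger inhibitor), the second highest of the three numbers shown. Compound 2 `CCNC(=O)c1noc(-c2cc(C(C)C)c(O)cc2O)c1-c1cc(CN)no1` gives 84 nM in this assay, within the scatter of compound 3, while compound 1 `CCNC(=O)c1noc(-c2cc(C(C)C)c(O)cc2O)c1-c1cc(COCC(=O)OC)no1` gives 262 nM, and a 2.2-fold lower number from compound 1 to compound 3 (0.34 log units; beyond the scatter). Compound 4 `CCNC(=O)c1noc(-c2cc(C(C)C)c(O)cc2O)c1-c1cc(CN2CCN(C)CC2)no1` differs from compound 3 by 4-methylpiperazin-1-yl in place of vinylamino on a saturated chain carbon bound to an aromatic carbon. Within the data shown here, two measured steps bear on this position: a 3.1-fold lower number from compound 1 to compound 2 (0.49 log units; beyond the scatter), and a 1.4-fold higher number from compound 2 to compound 3 (0.16 log units; within the scatter), so changes here have moved the number only modestly. Among the measured compounds shown here, no measured compound carries a ring at this place, so the step is expected to stay small: a 1.1-fold lower number from compound 3 to compound 4 (0.04 log units; within the scatter). Compound 4 is therefore estimated at 110 nM, with a range of 45 nM to 280 nM.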

Compound 4, half-maximal inhibitory concentration: 340 nM
The estimate for compound 4 lay 3.1-fold (0.49 log units) below the measured number; the measured number lies above the stated range.
By their numbers in this assay, from the lowest: compounds 2 and 3 (each within the scatter of the next); then compounds 1 and 4 (each within the scatter of the next).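

In this assay, a ring at this place raises the number, the first such rise beyond the scatter here (a 2.8-fold higher number from compound 3 to compound 4 (0.45 log units; beyond the scatter)), and the gap from the primary amine is similar (a 4.0-fold higher number from compound 2 to compound 4 (0.61 log units; beyond the scatter)). The 4-methylpiperazin-1-yl group leaves the number level with the (methoxycarbonyl)methoxy compound (a 1.3-fold higher number from compound 1 to compound 4 (0.11 log units; within the scatter)), so both amino compounds stand apart from these two. Nothing available explains the rise. Still open, as far as these compounds go, is whether the ring or its methyl group drives this change, and whether an unsubstituted piperazine or a morpholine would give a similar number.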